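Swapping bromo for cyano on the pendant phenyl ring

A few compounds are considered here, and "the series" means these few. Any claim that something is new, unique, unknown or untested is made for them only; others in the source may bear on it.

Compound 3 `Cn1cnnc1SCC(=O)N/N=c1/scc(-c2ccc(Br)cc2)n1-c1ccccc1` and compound 2 `Cc1ccc(-c2cs/c(=N/NC(=O)CSc3nncn3C)n2-c2ccccc2)cc1` share a core and differ only at one aromatic carbon. In an ADME assay on NIH3T3 cells (Mus musculus) for cytotoxicity, read by MTT assay, with a stated time of 24 h (on this read-out higher numbers stand for weaker inhibition and lower numbers for stronger inhibition), compound 2 gives 130 ug/mL. Compound 3 gives 58.3 ug/mL, the lowest of the two numbers shown. That gap is a 2.2-fold lower number from compound 2 to compound 3 (0.35 log units; beyond the scatter), a modest step that lies beyond the scatter. Compound 1 `N#Cc1ccc(-c2cs/c(=N/NC(=O)CSc3ncccn3)n2-c2ccccc2)cc1`, which carries a cyano group on the same ring but a different tail, reached only a limit of the assay, < 3.9 ug/mL; this is summarised as the limit of < 3.9 ug/mL in this assay, at which 1 of the 3 values shown sits.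

Compound 4 `Cn1cnnc1SCC(=O)N/N=c1/scc(-c2ccc(C#N)cc2)n1-c1ccccc1` is to be measured next. It differs from compound 3 by cyano in place of bromo on an aromatic carbon. Among the measured compounds shown here, no measured step covers exactly this bromo-to-cyano change, so the expectation rests on the cyano-bearing compound 1, which gave < 3.9 ug/mL, pointing toward a lower number than compound 3. The expected step is a 3.9-fold lower number from compound 3 to compound 4 (0.59 log units; beyond the scatter), a downward move beyond the scatter. Compound 4 is therefore estimated at 15 ug/mL, with a plausible range from 4 ug/mL to 60 ug/mL.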

Compound 4, half-maximal inhibitory concentration: 153 ug/mL
Compound 4: middle estimate off by 10-fold (1.01 log units), on the low side; the whole stated range lies below it.
By their numbers in this assay, from the lowest: compound 3; then compounds 2 and 4 (each within the scatter of the next). At a limit, below all of these: compound 1.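

In this assay, with the 4-methyl-4H-1,2,4-triazol-3-yl tail held fixed, the change from 4-bromophenyl to 4-cyanophenyl gives a 2.6-fold higher number from compound 3 to compound 4 (0.42 log units; beyond the scatter), so cyano does not lower the number at this ring carbon. Cyano and methyl at this carbon cannot be told apart, with a 1.2-fold higher number from compound 2 to compound 4 (0.07 log units; within the scatter). With cyano kept on both compounds, the change on the sulfur gives an at least 39-fold higher number from compound 1 to compound 4 (1.59 log units; beyond the scatter), so in this pair the low reading follows the tail and not the cyano, and that reading is a limit of the assay: the limit of < 3.9 ug/mL in this assay, at which 1 of the 4 values shown sits.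

On these data alone, it remains open whether the bromo-to-cyano step would look the same with the pyrimidin-2-yl tail. As far as these compounds go, it is also open how an amine or a carboxylic acid at this ring carbon would read.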